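The source may hold more compounds than are shown below. What is called first, only, known or untested is meant among the compounds shown, and "the series" means these compounds.

Among the compounds with values here, in an in vitro ADME assay on microsomes from liver (Mus musculus) for pharmacokinetics, read by LC-MS, with a stated time of 10 min, tested at 1 uM (on this read-out higher numbers stand for fast clearance and lower numbers for slow clearance), two compounds built on one shared core have numbers so far. Within the data shown here, compound 1 (`CN1C[C@H](C(=O)Nc2ccc(C(F)(F)F)cc2)[C@@H](c2ccc(/C=C/C(=O)Nc3ccccc3N)cc2)C1`) gives 23 mL/min/kg, and compound 2 (`CN1C[C@H](C(=O)Nc2ccc(Br)cc2)[C@@H](c2ccc(/C=C/C(=O)Nc3ccccc3N)cc2)C1`) gives 16 mL/min/kg, so compound 2 stands within the usual scatter of its only measured neighbour. Compound 3 (`CN1C[C@H](C(=O)Nc2cccc(F)c2)[C@@H](c2ccc(/C=C/C(=O)Nc3ccccc3N)cc2)C1`) keeps the same core but carries 3-fluorophenyl in place of 4-bromophenyl on an amide-type nitrogen. Among the measured compounds shown here, only one measured step bears on this change: a 1.4-fold lower number from compound 1 to compound 2 (0.16 log units; within the scatter), with bromo in place of trifluoromethyl on an aromatic carbon. For the measured compounds named here, that is thin guidance, since no measured compound carries 3-fluorophenyl and a single step cannot establish a trend. Going by the values given here, still, the one exchange seen at this end of the molecule did not move the number beyond the scatter, so no step beyond the scatter is expected in this assay here. The expected step is a 1.3-fold higher number from compound 2 to compound 3 (0.10 log units; within the scatter), and its direction is not firmly indicated by the data. For compound 3 the estimated value is 20 mL/min/kg, with an expected range from 10 mL/min/kg to 40 mL/min/kg.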

Compound 3, clearance: 56 mL/min/kg
Compound 3: middle estimate off by 2.8-fold (0.45 log units), on the low side; the whole stated range lies below it.
By their numbers in this assay, from the lowest: compounds 2 and 1 (each within the scatter of the next); then compound 3.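

In this assay, 3-fluorophenyl in place of 4-bromophenyl on the amide-type nitrogen gives a 3.5-fold higher number from compound 2 to compound 3 (0.54 log units; beyond the scatter) and 3-fluorophenyl in place of 4-(trifluoromethyl)phenyl at the same place gives a 2.4-fold higher number from compound 1 to compound 3 (0.39 log units; beyond the scatter) so both exchanges reach beyond the scatter. The earlier exchange at this position, a 1.4-fold lower number from compound 1 to compound 2 (0.16 log units; within the scatter) had not done so, and only with compound 3 does this end of the molecule prove able to shift the clearance measurably, with compound 1 and compound 2 remaining within the scatter of each other and both lower than compound 3. Nothing available here accounts for the rise.

The 3-fluorophenyl group differs from the other two groups both in its substituent and in the position printed in its name, so the compounds shown cannot say which of these two differences goes with the higher number. A 4-fluorophenyl group or a 3-bromophenyl group on the same amide-type nitrogen would separate the two, and an unsubstituted phenyl group would show where the series stands without any halogen or trifluoromethyl.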